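Quinoxaline-type diamines with varied aryl linkers: growth inhibition notes

The source may hold more compounds than are shown below. What is called first, only, known or untested is meant among the compounds shown, and "the series" means these compounds.

Of the compounds shown here, three of the shared core have been measured in a functional assay on SF-295 cells (Homo sapiens) for inhibition, read by sulforhodamine B assay, with a stated time of 48 h; on this read-out lower numbers stand for stronger inhibition of growth and higher numbers for weaker inhibition of growth. Compound 1 `Nc1cc(N)c2nc(-c3ccccc3)c(Oc3ccc(Cl)c(Cl)c3)nc2c1` gives 13800 nM. Compound 2 `Nc1cc(N)c2nc(-c3ccccc3)c(NCc3ccc(Cl)c(Cl)c3)nc2c1` gives 15500 nM in this assay. Compound 3 `CCOC(=O)[C@H](CCC(=O)O)NC(=O)c1ccc(Sc2nc3cc(N)cc(N)c3nc2-c2ccccc2)cc1` gives 25100 nM in this assay. Compound 1 has the lowest of the three numbers, but its nearest neighbour compound 2 and its furthest neighbour compound 3 both lie within the scatter of it, so no order among the three is established.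

Compound 4 `Nc1cc(N)c2nc(-c3ccccc3)c(Sc3ccc(F)cc3)nc2c1` is not yet measured. Its difference from compound 1 is (4-fluorophenyl)sulfanyl in place of 3,4-dichlorophenoxy on an aromatic carbon. The measured values of compound 1 and compound 3 both cluster within scatter of each other, so no step beyond the scatter is expected; the estimate means a step of a 1.3-fold higher number from compound 1 to compound 4 (0.12 log units; within the scatter). For compound 4 the expected value in this assay is 18000 nM, with a range from 7000 nM to 45000 nM.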

Compound 4, concentration for 50% growth inhibition: 13800 nM
The estimate for compound 4 lay 1.3-fold (0.12 log units) above the measured number, and the stated range covers the measured number.
By their numbers in this assay, from the lowest: compounds 1, 4, 2 and 3 (each within the scatter of the next).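

In this assay, among the compounds shown here, the exchange of 3,4-dichlorophenoxy for (4-fluorophenyl)sulfanyl on the aromatic carbon next to the ring nitrogen gives no change at the digits printed from compound 1 to compound 4 (within the scatter), the first step that alters one place only. At this position, the two aryl groups therefore cannot be told apart by growth inhibition. Nothing at hand bears on the reason for this result.

Still open, from the compounds shown here alone, is whether an amine or a carboxylic acid on the aryl ring, or a longer chain in place of the aryl group, would move the number beyond the scatter.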